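From 2-fluorophenyl to 2-chlorophenyl: working notes

The compounds below may be only part of what the source reports. "The series", "measured", "known", "first", "only" and "open" are said of these compounds alone.

In a functional assay on MCF7 cells (Homo sapiens) for cytotoxicity, read by MTT assay, with a stated time of 96 h (a lower number here means a stronger inhibitor, a higher number a weaker inhibitor), compound 1 `COc1cc(C(=O)c2cn(-c3ccccc3)cc2-c2ccccc2Cl)cc(OC)c1OC` gives 76 nM and compound 2 `COc1cc(C(=O)c2cn(-c3cccc(C)c3)cc2-c2ccccc2Cl)cc(OC)c1OC` gives 420 nM. Compound 3 `COc1cc(C(=O)c2cn(-c3cccc(N)c3)cc2-c2ccccc2F)cc(OC)c1OC`, at 17 nM, has the lowest number of the three, and its gaps to both others lie beyond the scatter.

Compound 4 `COc1cc(C(=O)c2cn(-c3cccc(N)c3)cc2-c2ccccc2Cl)cc(OC)c1OC` is not yet measured. It differs from compound 3 as follows: chloro in place of fluoro on an aromatic carbon. This is chloro in place of fluoro on an aromatic carbon, ortho to a large group.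

Among the measured compounds shown here, no measured step covers this exchange. For the measured compounds named here, the only measured step is a 5.5-fold higher number from compound 1 to compound 2 (0.74 log units; beyond the scatter), a modest one beyond the scatter, but it is methyl in place of hydrogen at another place and sets no size here. Compound 1 carries the chloro, but it differs from compound 3 in more than one place, so the value of compound 1 at 76 nM only hints at a higher number.

The step expected is a 1.8-fold higher number from compound 3 to compound 4 (0.25 log units; within the scatter), small and not expected to exceed the scatter. For compound 4 the estimated value is 30 nM, with an expected range of 9 nM to 100 nM.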

Compound 4, half-maximal inhibitory concentration: 40 nM
Beside the measured number, compound 4's estimate is 1.3-fold (0.12 log units) below it; the measured number falls inside the stated range.
By their numbers in this assay, from the lowest: compound 3; then compounds 4 and 1 (each within the scatter of the next); then compound 2.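

Among the compounds shown here, with the amino group held fixed in this assay, chloro in place of fluoro on an aromatic carbon, ortho to a large group, gives a 2.4-fold higher number from compound 3 to compound 4 (0.37 log units; beyond the scatter), the first direct reading of this exchange, and the 2-fluorophenyl compound keeps the lower number. With the 2-chlorophenyl present in all three compounds, amino in place of methyl gives an 11-fold lower number from compound 2 to compound 4 (1.02 log units; beyond the scatter), the largest step read so far in the series. Amino in place of hydrogen gives a 1.9-fold lower number from compound 1 to compound 4 (0.28 log units; within the scatter), so these two compounds are not told apart, and only the methyl compound stands clear of them.

As far as these compounds go, whether the exchange of fluoro for chloro reads the same without the amino group, and how bromo or methoxy would read at the same place, remains open. Nothing available bears on the reason for any of these steps.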